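Removing the side chain from compound 2

The source may report more compounds than this note shows. Statements on the series, on what has been measured and on what is new or still open speak of the compounds shown alone.

compound 1 `Nc1nc2[nH]c(CCCCCC(=O)N[C@@H](CCC(=O)O)C(=O)O)cc2c(=O)[nH]1`: 214 nM
compound 2 `Nc1nc2[nH]c(CCCCCCCCC(=O)N[C@@H](CCC(=O)O)C(=O)O)cc2c(=O)[nH]1`: 3.99 nM

In a functional assay on D4 cells (Cricetulus griseus) for inhibition, read by CellTiter-Blue, with a stated time of 96 h (on this read-out higher numbers stand for weaker inhibition and lower numbers for stronger inhibition), compound 2 holds the lower of the two numbers at 3.99 nM and compound 1 stands at 214 nM, a gap that lies beyond the scatter. Compound 3 `Nc1nc2[nH]c(CCCCCCCCC(=O)O)cc2c(=O)[nH]1` has hydroxy in place of (1,3-dicarboxypropyl)amino on a carbonyl carbon. Among the compounds with values here, no measured pair shows this change, and both measured compounds keep (1,3-dicarboxypropyl)amino, so the expectation is loose. A large step toward weaker inhibition is expected, estimated as a 750-fold higher number from compound 2 to compound 3 (2.88 log units; beyond the scatter). For compound 3 the estimated value is 3000 nM, with an expected range of 300 nM to 30000 nM.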

Compound 3, half-maximal inhibitory concentration: > 1000 nM
Compound 3: only a limit was reported (the forecaster's own chance of this, stated with the estimate: 50%); the middle value is on the limit's open side.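

In this assay, hydroxy in place of (1,3-dicarboxypropyl)amino on a carbonyl carbon gives an at least 250-fold higher number from compound 2 to compound 3 (2.39 log units; beyond the scatter). Within the data shown here, compound 1 and compound 2 both keep (1,3-dicarboxypropyl)amino, so this step is the first reading of what that group contributes, and the contribution is large. For compound 3 the reported figure is a limit, not a number: the limit of > 1000 nM in this assay, at which 1 of the 3 values shown sits.

Which part of (1,3-dicarboxypropyl)amino carries the difference remains open. So does how methylamino would read on the same carbonyl carbon.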